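The source may hold more compounds than are shown below. What is called first, only, known or untested is meant among the compounds shown, and "the series" means these compounds.

Working notes on the series. Among the measured compounds shown here, in a functional assay on liver (Sus scrofa) for inhibition of squalene monooxygenase (Homo sapiens), using microsomes (on this read-out higher numbers stand for weaker inhibition and lower numbers for stronger inhibition), compound 1 `CCN(C/C=C/C#CC(C)(C)C)Cc1cccc(OC[Si](C)(C)c2ccc(Br)cc2)c1` gives 210 nM and compound 2 `CCN(C/C=C/C#CC(C)(C)C)Cc1cccc(OC[Si](C)(C)c2ccc(OC)cc2)c1` gives 870 nM, the higher of the two numbers; the only measured step is a 4.1-fold higher number from compound 1 to compound 2 (0.62 log units; beyond the scatter). Compound 3 `CCN(C/C=C/C#CC(C)(C)C)Cc1cccc(OC[Si](C)(C)c2ccc(O)cc2)c1` carries hydrogen in place of methyl on an oxygen on an aromatic ring, that is, hydrogen in place of methyl on an oxygen on an aromatic ring. For the measured compounds named here, no measured step touches this oxygen; the step from compound 1 to compound 2 changed the ring substituent itself and does not transfer directly. The expectation is therefore a step of at most modest size, a 1.4-fold higher number from compound 2 to compound 3 (0.14 log units; within the scatter), in either direction, and for compound 3 an estimated 1200 nM (range 400 nM to 3600 nM).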

Compound 3, half-maximal inhibitory concentration: 8000 nM
Compound 3: the middle estimate sits 6.7-fold (0.82 log units) below what was measured; the whole stated range lies below it.
By their numbers in this assay, from the lowest: compound 1; then compound 2; then compound 3.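

In this assay the methyl on this oxygen counts for a good deal: methoxy to hydroxy gives a 9.2-fold higher number from compound 2 to compound 3 (0.96 log units; beyond the scatter) and leaves compound 3 with the highest number of the three. Set against the bromo, the hydroxy gives a 38-fold higher number from compound 1 to compound 3 (1.58 log units; beyond the scatter) on the same aromatic carbon, so this substituent spans a wide range of numbers. Nothing at hand bears on why the free hydroxy fares so poorly.

The compounds shown leave open whether ethoxy, chloro or an amine at this place would sit nearer compound 1 or compound 3.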